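A Halogen Swap Among Compounds Without a Measured Dose

This account rests on a few compounds, and the source may have more. Where it says the series, first, only, none or still open, it means among the compounds named here.

Three esters sharing one core have been tested in a functional assay on the whole organism (strain Kunming) with Mus musculus as the target, with a stated time of 0.5 h; on this read-out higher numbers stand for an effect only at larger amounts of compound and lower numbers for an effect already at smaller amounts. Compound 1 `COc1cc(OC)c(OC)cc1/C=C/COC(=O)/C=C/c1c(OC)ccc(OC)c1OC` gives > 300 mg/kg, which is a limit and not a number. Compound 2 `COc1cc(OC)c(OC)cc1/C=C/COC(=O)/C=C/c1ccc(Br)cc1` gives > 300 mg/kg, which is also a limit. Compound 3 `COc1cc(OC)c(OC)cc1/C=C/COC(=O)/C=C/c1cc(OC)c(OC)c(OC)c1` gives > 200 mg/kg, a limit once more. Going by the values given here, compound 2 thus stands with the other two: none of the three has a measured dose, so no step among them can be read.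

Compound 4 `COc1cc(OC)c(OC)cc1/C=C/COC(=O)/C=C/c1ccccc1Cl` has not yet been measured. It differs from compound 2 in one place: 2-chlorophenyl in place of 4-bromophenyl on a double-bonded chain carbon bound to a double-bonded chain carbon. In words, 2-chlorophenyl stands in place of 4-bromophenyl on a double-bonded chain carbon bound to a double-bonded chain carbon.

Among the compounds with values here, with no measured step to draw on, the expectation rests on compound 2 and its limit of > 300 mg/kg. The expected change is an at least 1.0-fold lower number from compound 2 to compound 4 (0.02 log units; that floor lies within the scatter), no larger than the scatter. For compound 4 the estimate is 280 mg/kg, with an expected range from 130 mg/kg to 600 mg/kg.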

Compound 4, dose for half-maximal effect: 248 mg/kg
Compound 4: middle estimate off by 1.1-fold (0.05 log units), on the high side; measured number inside the range.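

Putting 2-chlorophenyl in place of 4-bromophenyl on a double-bonded chain carbon bound to a double-bonded chain carbon gives an at least 1.2-fold lower number from compound 2 to compound 4 (0.08 log units; that floor lies within the scatter). Going by these compounds alone, this makes compound 4 the first compound here with a measured dose in this assay, showing that this place can carry a group that brings the effect within the tested doses. The true size of the step stays unknown because compound 2 has only a limit and not a number: the limit of > 300 mg/kg in this assay, at which 2 of the 4 values shown sit.

The change swaps the halogen and moves it on the ring in one step, so these compounds cannot tell which of the two matters. From the compounds shown here alone, how a group of a different kind, such as an aminophenyl or a carboxyphenyl, would read at this place also remains open.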